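The source may hold more compounds than are shown below. What is called first, only, known or untested is meant among the compounds shown, and "the series" means these compounds.

In a physicochemical assay for lipophilicity, read by LC-MS, in phosphate buffer, measured as octanol-water partition, with a stated time of 30 min, at pH 7.4, tested at 200 mM (a higher number here means a more lipophilic compound, a lower number a more polar compound), compound 3 `Cn1c(COc2cccc(C(=O)O)c2)nc2ccc(Oc3cc(Cl)ccn3)cc21` gives 1.2, level with compound 2 `Cn1c(COc2cccc(C(=O)O)c2)nc2ccc(Oc3ccc(Cl)cn3)cc21` at 1.2. Compound 1 `Cc1ccc(Oc2ccc3nc(COc4cccc(C(=O)O)c4)n(C)c3n2)cc1F`, which differs from both in more than one place, stands higher at 2.1. The structure to be measured next is compound 4 `Cc1cccc(Oc2ccc3nc(COc4cccc(C(=O)O)c4)n(C)c3c2)n1`, and the change is 6-methylpyridin-2-yl in place of 4-chloropyridin-2-yl on an oxygen on an aromatic ring. Among the compounds with values here, the one measured step that bears on this is no change at the digits printed from compound 2 to compound 3 (within the scatter), with 4-chloropyridin-2-yl in place of 5-chloropyridin-2-yl. Within the data shown here, no measured step exchanges chloro for methyl, so the support is indirect. No shift beyond the scatter is expected, and the estimated step is a number 0.10 log units lower from compound 3 to compound 4 (within the scatter). For compound 4 the estimated value is 1.1, with an expected range of 0.7 to 1.6.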

Compound 4, distribution coefficient: 0.8
Compound 4: middle estimate off by 0.30 log units, on the high side; the measured number falls inside the stated range.
By their numbers in this assay, from the lowest: compound 4; then compounds 2 and 3 (each within the scatter of the next); then compound 1.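

In this assay, the group on this oxygen can move the number: 6-methylpyridin-2-yl in place of 4-chloropyridin-2-yl gives a number 0.40 log units lower from compound 3 to compound 4 (beyond the scatter), and 6-methylpyridin-2-yl in place of 5-chloropyridin-2-yl gives a number 0.40 log units lower from compound 2 to compound 4 (beyond the scatter). Shifting the chloro around the ring had produced no step beyond the scatter, whereas this exchange of ring substituent does. No measurement shown accounts for the shift. The names show that the substituent and its ring position change together, leaving their contributions unseparated. On these data alone, how an amine or a longer chain on this ring would read remains open.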